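The source may hold more compounds than are shown below. What is called first, only, known or untested is meant among the compounds shown, and "the series" means these compounds.

Measured so far in a functional assay on B16 cells (Mus musculus) for inhibition; a higher number here means a weaker inhibitor, a lower number a stronger inhibitor
- compound 1 `CC(C)CN(CC(=O)NN(Cc1ccccc1)c1cnccn1)NC(=O)CBr` gives 11400 nM
- compound 2 `CC(C)CN(CC(=O)N(CC(C)C)NC(=O)OCc1ccccc1)/N=C/c1cccc(B(O)O)c1` gives 53900 nM

Compound 1 (11400 nM) has the lower of the two numbers and is the stronger inhibitor, with compound 2 beyond the scatter from it. Compound 3 `CC(C)CN(CC(=O)NN(Cc1ccccc1)c1cnccn1)/N=C/c1cccc(B(O)O)c1` has not yet been measured in this assay. It keeps the core of compound 1 and loses the ((bromomethyl)carbonyl)amino group. The change is a group of 11 heavy atoms (7 carbon, 1 boron, 1 nitrogen, 2 oxygen; one six-membered aromatic ring of carbon only) in place of a group of 5 heavy atoms (2 carbon, 1 nitrogen, 1 oxygen, 1 bromine; no ring), on an amine nitrogen and the rest of the structure stays the same.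

Going by the values given here, no measured pair isolates this change, so the expectation rests on thin evidence. The entering group also stands in compound 2 (53900 nM), whose number is the higher one. A moderate step to a higher number, meaning a weaker inhibitor, is therefore expected in this assay, only modestly beyond the scatter. The expected change is a 2.5-fold higher number from compound 1 to compound 3 (0.39 log units; beyond the scatter), and this remains an estimate. For compound 3 the estimated value is 28000 nM, with an expected range from 9000 nM to 80000 nM.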

Compound 3, half-maximal inhibitory concentration: > 80000 nM
Compound 3: a limit, no number; the forecaster's own chance of this, stated with the estimate: 15%; middle value at least 2.8-fold (0.45 log units) from the limit.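

In this assay, the amine nitrogen of the core of compound 1 is a place where the substituent matters: exchanging the ((bromomethyl)carbonyl)amino group for the boron-bearing aromatic group gives an at least 7.0-fold higher number from compound 1 to compound 3 (0.84 log units; beyond the scatter). This is the only pair shown that differs in one place, so the gap between compound 1 and compound 2 could not be tied to any single change, whereas this step can be tied to this one. On this core, the ((bromomethyl)carbonyl)amino group goes with the stronger inhibitor, and the value of compound 3 is a limit rather than a number, so the step has a lower bound and no upper end: the limit of > 80000 nM in this assay, at which 1 of the 3 values shown sits.

From the compounds shown here alone, how far compound 3 lies beyond its limit stays open, as does whether the step comes from losing the ((bromomethyl)carbonyl)amino group or from gaining the boron-bearing aromatic group. Also open, going by these compounds, is what an acetylamino group, which keeps the carbonyl and lacks the bromine, would give on the same amine nitrogen.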